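The compounds below may be only part of what the source reports. "The series", "measured", "known", "first", "only" and "open" are said of these compounds alone.

In a functional assay (aorta) with Rattus norvegicus as the target (on this read-out higher numbers stand for higher potency (the scale is a negative logarithm) and lower numbers for lower potency), two compounds built on one shared core have been measured. Compound 1 `CC1(C)C=C(n2ccccc2=O)c2cc(C(=O)c3ccc(O)cc3)ccc2O1` gives 6.65, and compound 2 `CC1(C)C=C(n2ccccc2=O)c2cc(C(=O)c3ccccc3C(F)(F)F)ccc2O1` gives 6.76. Going by the values given here, these two numbers sit within the scatter of each other, so compound 1 has no measured neighbour that it clearly differs from; the only step, a number 0.11 log units higher from compound 1 to compound 2 (within the scatter), came from 2-(trifluoromethyl)phenyl in place of 4-hydroxyphenyl on a carbonyl carbon.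

Compound 3 `CC1(C)C=C(n2ccccc2=O)c2cc(OS(=O)(=O)F)ccc2O1` has not yet been measured in this assay. Its change from compound 1 is (fluorosulfonyl)oxy in place of (4-hydroxyphenyl)carbonyl on an aromatic carbon. Among the compounds with values here, the one measured step bears on it only loosely: it exchanged one group on the carbonyl carbon for another while keeping the carbonyl, and it stayed within the scatter. Within the data shown here, no measured step removes the whole (4-hydroxyphenyl)carbonyl or brings in a group with no ring. With that thin footing, a modest loss is expected, held with little confidence: compound 3 is estimated at 6.2, within a range from 5.4 to 7. That estimate means an expected step of a number 0.45 log units lower from compound 1 to compound 3 (beyond the scatter).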

Compound 3, logarithm of the reciprocal of the active concentration, log(1/C): 7.95
The estimate for compound 3 lay 1.75 log units below the measured number; measured number above the stated range.
By their numbers in this assay, from the lowest: compounds 1 and 2 (each within the scatter of the next); then compound 3.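

In this assay, the aromatic carbon of the shared core turns out not to need the (4-hydroxyphenyl)carbonyl: (fluorosulfonyl)oxy in its place gives a number 1.30 log units higher from compound 1 to compound 3 (beyond the scatter) and leaves compound 3 clearly above compound 1. The earlier pair kept the carbonyl and a ring and changed only the group on the carbonyl carbon, so it could not show that a group with no ring and fewer heavy atoms can sit here with a clear gain. This single swap changes the ring, the carbonyl and the hydroxyl together, and nothing measured here explains the gain.

The compounds shown do not settle whether the gain comes from the incoming (fluorosulfonyl)oxy or from losing the (4-hydroxyphenyl)carbonyl. A methoxy group, an amine or a plain hydrogen on this same carbon would help separate the two.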